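Series notes: amide variation on the shared core

This account rests on a few compounds, and the source may have more. Where it says the series, first, only, none or still open, it means among the compounds named here.

Compound 3 `O=C(NCc1ccc(CNS(=O)(=O)c2ccccc2)cc1)c1c(Cl)cc(Cl)cc1Cl` sits second highest of the three numbers in hand in an assay on MDA-MB-231 cells for binding affinity to C-X-C chemokine receptor type 4 (Homo sapiens), read by immunofluorescence and microscopy, with stated times of 10 min and 30 min (on this read-out lower numbers stand for an effect already at smaller amounts and higher numbers for an effect only at larger amounts of compound), where compound 3 gives 10 nM. Its nearest neighbour is compound 1 `O=C(NCc1ccc(CNS(=O)(=O)c2ccccc2)cc1)c1ccc([N+](=O)[O-])cc1`, which in this assay gives 100 nM, and the furthest is compound 2 `Cc1ccccc1C(=O)NCc1ccc(CNS(=O)(=O)c2ccccc2)cc1`, which gives 1 nM. The steps that frame it are a 10-fold lower number from compound 1 to compound 3 (1.00 log units; beyond the scatter) and a 10-fold higher number from compound 2 to compound 3 (1.00 log units; beyond the scatter), with the larger 100-fold lower number from compound 1 to compound 2 (2.00 log units; beyond the scatter) spanning the whole set.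

Compound 4 `O=C(NCc1ccc(CNS(=O)(=O)c2ccccc2)cc1)c1ccccc1Cl` is unmeasured. It differs from compound 3 in one place: 2-chlorophenyl in place of 2,4,6-trichlorophenyl on a carbonyl carbon.

Going by the values given here, only the step from compound 2 bears directly on this change, since it also swaps a 2,4,6-trichlorophenyl for a group bearing a single substituent on the carbonyl carbon. That step, a 10-fold higher number from compound 2 to compound 3 (1.00 log units; beyond the scatter), went in the direction of a higher number when 2,4,6-trichlorophenyl entered; removing two chlorines and leaving 2-chlorophenyl is expected to reverse part of it. A lower number beyond the scatter is therefore expected, though 2-chlorophenyl is not 2-methylphenyl, so not the full reversal. The expected step is a 3.3-fold lower number from compound 3 to compound 4 (0.52 log units; beyond the scatter). Compound 4 is estimated at 3 nM, with a range from 1 nM to 10 nM.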

Compound 4, effective concentration (reported as EC, without a stated level of effect): 10 nM
Estimate against measurement, compound 4: 3.3-fold (0.52 log units) below; the range from low to high includes it.
By their numbers in this assay, from the lowest: compound 2; then compounds 3 and 4 (each within the scatter of the next); then compound 1.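

In this assay, taking two chlorines off the 2,4,6-trichlorophenyl to leave 2-chlorophenyl gives no change at the digits printed from compound 3 to compound 4 (within the scatter), so on this carbonyl carbon the two chlorinated groups cannot be told apart and the number of chlorines carries no readable difference in this pair. Going by these compounds alone, the series now also holds a change of a single atom on the aromatic ring: chloro in place of methyl gives a 10-fold higher number from compound 2 to compound 4 (1.00 log units; beyond the scatter), a step the same size as the one printed from compound 2 to compound 3, so the gap to compound 2 appears already with the single chlorine, without the other two. Compared with the 4-nitrophenyl group, 2-chlorophenyl gives a 10-fold lower number from compound 1 to compound 4 (1.00 log units; beyond the scatter), which places compound 4 with compound 3 and apart from compound 1 and compound 2. Nothing measured here accounts for these steps.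

As far as these compounds go, whether the lower number of compound 2 belongs to methyl alone, or would persist with an ethyl group or a methoxy group on that aromatic carbon, remains open. A plain phenyl on the carbonyl carbon would show whether the chloro or the methyl moves the number at all.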